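The source may hold more compounds than are shown below. What is called first, only, known or untested is meant among the compounds shown, and "the series" means these compounds.

Three compounds have been run in a functional assay on MIA PaCa-2 cells (Homo sapiens) for inhibition, read by MTT assay, with a stated time of 3 days (on this read-out lower numbers stand for stronger inhibition and higher numbers for weaker inhibition), and none gives a number. Compound 1 `CCOC(=O)[C@@H]1CCCN(S(=O)(=O)c2ccc(S(=O)(=O)N(CC)C(C)C)cc2)C1` returns only a limit of the assay, > 10000 nM. Compound 2 `CCOC(=O)C1CCCCN1S(=O)(=O)c1ccc(S(=O)(=O)N(CC)CC)cc1` likewise returns only a limit, > 10000 nM. Compound 3 `CC(C)c1noc(N2CCN(C(=O)[C@@H]3CCCN(S(=O)(=O)c4ccc(S(=O)(=O)NC(C)(C)C)cc4)C3)CC2)n1` also sits at a limit in this assay, > 10000 nM. Among the compounds with values here, no two measured compounds differ in a single place, so no step between measured compounds can be counted; what the numbers show is that every value sits at the limit of > 10000 nM in this assay, at which 3 of the 3 values shown sit.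

Compound 4 `CC(C)c1noc(N2CCN(C(=O)[C@@H]3CCCN(S(=O)(=O)c4ccc(S(=O)(=O)NC5CCC5)cc4)C3)CC2)n1` has not been measured. It differs from compound 3 in one place, on the sulfonamide nitrogen: cyclobutyl in place of tert-butyl on a sulfonamide nitrogen. Within the data shown here, with every measured value at a limit, there is no measured step to point in either direction, and the expectation for the step that the limit leaves unreadable from compound 3 to compound 4 is none beyond the scatter. Compound 4 is therefore expected to give about 15000 nM in this assay, with a range from 5000 nM to 50000 nM, and most probably again only a limit rather than a number.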

Compound 4, half-maximal inhibitory concentration: > 10000 nM
Compound 4: a limit, no number; the forecaster's own chance of this, stated with the estimate: 85%; the middle value does not contradict the limit.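

No step can be read from compound 3 to compound 4 in this assay, since both results are limits and not numbers. The compounds shown leave open whether any change to the shared core gives a number on this read-out: the limit of > 10000 nM in this assay, at which 4 of the 4 values shown sit.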